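Trifluoromethyl for fluoro on compound 2

A few compounds are considered here, and "the series" means these few. Any claim that something is new, unique, unknown or untested is made for them only; others in the source may bear on it.

compound 1 `CN1C/C(=C\c2cccc([N+](=O)[O-])c2)C(=O)/C(=C/c2ccccc2F)C1`: 1010 nM
compound 2 `CN1C/C(=C\c2ccc(F)cc2)C(=O)/C(=C/c2cccc([N+](=O)[O-])c2)C1`: 7160 nM
compound 3 `CN1C/C(=C\c2cccc(Br)c2)C(=O)/C(=C/c2cccc([N+](=O)[O-])c2)C1`: 4030 nM

Compound 2 and compound 3 stand together at the high end of the numbers in a functional assay on THP-1 cells (Homo sapiens) for cytotoxicity, read by MTT assay, with a stated time of 24 h (a higher number here means a weaker inhibitor, a lower number a stronger inhibitor), and cannot be separated (a 1.8-fold lower number from compound 2 to compound 3 (0.25 log units; within the scatter)), while compound 1 lies clearly lower. Compound 4 `CN1C/C(=C\c2ccc(C(F)(F)F)cc2)C(=O)/C(=C/c2cccc([N+](=O)[O-])c2)C1` differs from compound 2 by trifluoromethyl in place of fluoro on an aromatic carbon, with trifluoromethyl in place of fluoro on an aromatic carbon, para to a large group. Among the compounds with values here, no measured step makes this exact change. The nearest evidence comes from other swaps of the same group. Within the data shown here, two are modest and both involve compound 1 (a 7.1-fold higher number from compound 1 to compound 2 (0.85 log units; beyond the scatter) and a 4.0-fold higher number from compound 1 to compound 3 (0.60 log units; beyond the scatter)), whereas the one without compound 1 stayed within the scatter. A step beyond the scatter is therefore not expected. Compound 4 is estimated at 5000 nM, with an expected range of 2000 nM to 12000 nM. The expected change is a 1.4-fold lower number from compound 2 to compound 4 (0.16 log units; within the scatter), which would lie within the scatter.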

Compound 4, half-maximal inhibitory concentration: 970 nM
The estimate for compound 4 lay 5.2-fold (0.71 log units) above the measured number, outside the stated range (below it).
By their numbers in this assay, from the lowest: compounds 4 and 1 (each within the scatter of the next); then compounds 3 and 2 (each within the scatter of the next).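

On the aromatic carbon para to a large group, the group itself matters in this assay: trifluoromethyl in place of fluoro gives a 7.4-fold lower number from compound 2 to compound 4 (0.87 log units; beyond the scatter). The earlier steps shown here replaced one substituted phenyl with another, and the substituent moved or changed along with its place. Here the place stays the same, only the group on it changes, and the step still lies beyond the scatter.

On these data alone, whether an amine, a carboxylic acid or a longer chain at this place would follow trifluoromethyl or fluoro remains open. Nothing given on these compounds offers a cause for the step.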